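This account rests on a few compounds, and the source may have more. Where it says the series, first, only, none or still open, it means among the compounds named here.

Compound 1 `COc1cccc(/C=C/C(=O)Nc2cc(C(=O)c3cc(OC)c(OC)c(OC)c3)ccc2OC)c1` gives 3100 nM in a functional assay on B16 cells (Mus musculus) for cytotoxicity, read by MTT assay, with a stated time of 72 h; on this read-out lower numbers stand for stronger inhibition and higher numbers for weaker inhibition. Compound 2 `COc1cc(C(=O)c2cc(OC)c(OC)c(OC)c2)cc(NC(=O)/C=C/c2cc(OC)c(OC)c(OC)c2)c1OC` gives 2500 nM in this assay. Compound 3 `COc1ccc(/C=C/C(=O)Nc2cc(C(=O)c3cc(OC)c(OC)c(OC)c3)cc(OC)c2OC)cc1` gives 9400 nM in this assay.

Compound 3 stands highest of the three, with compound 1 nearest and compound 2 furthest. Compound 4 `COc1cccc(/C=C/C(=O)Nc2cc(C(=O)c3cc(OC)c(OC)c(OC)c3)cc(OC)c2OC)c1` differs from compound 3 by 3-methoxyphenyl in place of 4-methoxyphenyl on a double-bonded chain carbon bound to a double-bonded chain carbon. Within the data shown here, no measured step compares these two groups on the same core; the only step at this position is a 3.8-fold higher number from compound 2 to compound 3 (0.58 log units; beyond the scatter). Compound 1, which carries the 3-methoxyphenyl on a different core, shows a lower number than compound 3, so a moderate drop is expected, but uncertain. Compound 4 is estimated at 5000 nM in this assay, between 2000 nM and 14000 nM, a change of a 1.9-fold lower number from compound 3 to compound 4 (0.27 log units; within the scatter).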

Compound 4, half-maximal inhibitory concentration: 6700 nM
The estimate for compound 4 lay 1.3-fold (0.13 log units) below the measured number, and the stated range covers the measured number.
By their numbers in this assay, from the lowest: compounds 2 and 1 (each within the scatter of the next); then compounds 4 and 3 (each within the scatter of the next).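

Moving the single methoxy from the 4-methoxyphenyl to the 3-methoxyphenyl arrangement gives no change that can be told from scatter (a 1.4-fold lower number from compound 3 to compound 4 (0.15 log units; within the scatter)). The 3,4,5-trimethoxyphenyl group still gives the lower number against this 3-methoxyphenyl group (a 2.7-fold higher number from compound 2 to compound 4 (0.43 log units; beyond the scatter)), as it did against the 4-methoxyphenyl group. On the core, methoxy in place of hydrogen on an aromatic carbon gives a modest increase (a 2.2-fold higher number from compound 1 to compound 4 (0.33 log units; beyond the scatter)), so that site also affects the number.

As far as these compounds go, whether an amine or a carboxylic acid on the chain's aromatic ring would lower the number remains open. Nothing available explains why these numbers differ.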